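This account rests on a few compounds, and the source may have more. Where it says the series, first, only, none or still open, it means among the compounds named here.

Measured compounds:
compound 1, `COC1=C(CC(C)(C)CNC(=O)c2ccc3ccccc3c2)C(=O)c2ccccc2C1=O`, 52500 nM
compound 2, `COC1=C(CC(C)(C)CNC(=O)c2ccc3ccccc3c2OC)C(=O)c2ccccc2C1=O`, 95700 nM
compound 3, `COc1c(C(=O)NCC(C)(C)CC2=C(O)C(=O)c3ccccc3C2=O)ccc2ccccc12`, 39800 nM

These three values come from a functional assay on MCF7 cells (Homo sapiens) for cytotoxicity, read by resazurin assay, with a stated time of 3 days; a lower number here means a stronger inhibitor, a higher number a weaker inhibitor. Among them compound 2 gives the highest number; compound 1 stands nearest, a step of a 1.8-fold higher number from compound 1 to compound 2 (0.26 log units; within the scatter), and compound 3 stands furthest, a step of a 2.4-fold lower number from compound 2 to compound 3 (0.38 log units; beyond the scatter). Going by the values given here, all three numbers sit in a narrow band, and only the step to compound 3 lies beyond the scatter.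

Compound 4, `COC1=C(CC(C)(C)CNC(=O)c2cc(OC)c3ccccc3c2OC)C(=O)c2ccccc2C1=O`, has not yet been measured in this assay. It differs from compound 2 in one place: methoxy in place of hydrogen on an aromatic carbon. Among the compounds with values here, the one measured step that bears on this change is the step from compound 1 to compound 2, which is also a methoxy entering in place of hydrogen on an aromatic carbon of the same ring system; that step, a 1.8-fold higher number from compound 1 to compound 2 (0.26 log units; within the scatter), lay within the scatter. The step from compound 2 to compound 3 concerns a different change and is not a guide here. On this basis no step beyond the scatter is expected in this assay from compound 2 to compound 4, with at most a slight drift toward a higher number, a 1.1-fold higher number from compound 2 to compound 4 (0.06 log units; within the scatter). Compound 4 is therefore estimated at 110000 nM, within a range of 50000 nM to 250000 nM.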

Compound 4, half-maximal inhibitory concentration: "not active" (no number reported)
Compound 4: no number reported, so the estimate cannot be set against anything.
By their numbers in this assay, from the lowest: compounds 3, 1 and 2 (each within the scatter of the next, the first and the last beyond it).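

Going by these compounds alone, compound 4 was reported as not active in this assay with no number attached, so no step from compound 2 to compound 4 can be read. Nothing measured here accounts for this result. The compounds shown leave open how far the second methoxy on the aromatic ring shifts the number from that of compound 2.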